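The source may report more compounds than this note shows. Statements on the series, on what has been measured and on what is new or still open speak of the compounds shown alone.

Measured compounds:
compound 1 `CC1=C(C(=O)OCc2ccccc2)C(c2cccs2)NC(=O)N1` — 8%
compound 2 `CC1=C(C(=O)C2CC2)C(c2cccs2)NC(=O)N1` — 15%
compound 3 `CC1=C(C(=O)CC(C)C)C(c2cccs2)NC(=O)N1` — 18%

In an assay on membranes from HeLa cells for displacement of a labelled ligand from adenosine receptor A3 (Homo sapiens), read by scintillation counting, with a stated time of 180 min, tested at 1 uM (on this read-out higher numbers stand for more inhibition at the one concentration tested (going by the name of the read-out) and lower numbers for less inhibition), compound 3 gives 18%, the highest of the three numbers. Its nearest neighbour is compound 2, and the step of a number 3 percentage points higher from compound 2 to compound 3 (within the scatter) lies within the usual scatter, so the two cannot be told apart. Compound 1, furthest away, gives 8%, and that gap too is within the scatter. All three compounds, which share one core and differ only in the group on a carbonyl carbon, therefore sit at about the same low level.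

Compound 4 `CCC(CC)OC(=O)C1=C(C)NC(=O)NC1c1cccs1` is the next in this line. The change from compound 3 is (pentan-3-yl)oxy in place of isobutyl on a carbonyl carbon. Among the measured compounds shown here, the one measured step that bears on it, a number 3 percentage points higher from compound 2 to compound 3 (within the scatter), swapped one carbon group on that carbonyl carbon for another and moved the number only within the scatter. Compound 1, which like compound 4 carries an oxygen-linked group on a carbonyl carbon, shows a number within the scatter of compound 3. Nothing here points to a step beyond the scatter in either direction. For compound 4 the expected step is a number 6 percentage points lower from compound 3 to compound 4 (within the scatter). Compound 4 is estimated at 12%, within a range from 0% to 25%.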

Compound 4, a percentage reported as inhibition, at one concentration (the size of the read-out at that concentration, not a potency): 1%
Compound 4: the middle estimate sits 11 percentage points above what was measured, and the stated range covers the measured number.
By their numbers in this assay, from the lowest: compounds 4, 1, 2 and 3 (each within the scatter of the next, the first and the last beyond it).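

In this assay, putting (pentan-3-yl)oxy in place of isobutyl on a carbonyl carbon gives a number 17 percentage points lower from compound 3 to compound 4 (beyond the scatter), and putting it in place of cyclopropyl gives a number 14 percentage points lower from compound 2 to compound 4 (beyond the scatter). Among the compounds shown here, these are the first steps at this position to go beyond the scatter, so the group on this carbonyl carbon can change the read-out, though only modestly. The comparison between the two oxygen-linked groups gives a number 7 percentage points lower from compound 1 to compound 4 (within the scatter), so pentan-3-yl and benzyl on that oxygen cannot be told apart, and any split between oxygen-linked and carbon-linked groups is incomplete: compound 1 stays within the scatter of compound 2 and compound 3, and no measurement available here accounts for the lower number of compound 4.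

These readings come from a single concentration and all lie at a low level, so they give no measure of potency. On these data alone, how an amine on this carbonyl carbon, a methoxy group or a longer straight chain would read remains open, as does whether any group at this position could raise the number well above that of compound 3.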